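The compounds below may be only part of what the source reports. "The series", "measured", "known", "first", "only" and "open" are said of these compounds alone.

Working notes on the series. Compound 1 `CCCCCCCCc1cn([C@H]2C[C@@H]3OP(=O)(O)OC[C@H]3O2)c(=O)[nH]c1=O`, compound 2 `CCCCCCc1cn([C@H]2C[C@@H]3OP(=O)(O)OC[C@H]3O2)c(=O)[nH]c1=O` and compound 3 `CCCCCc1cn([C@H]2C[C@H](O)[C@@H](CO)O2)c(=O)[nH]c1=O` have been measured in a functional assay on Raji cells (Homo sapiens); on this read-out lower numbers stand for stronger inhibition and higher numbers for weaker inhibition; compound 4 `CCCc1cn([C@H]2C[C@H](O)[C@@H](CO)O2)c(=O)[nH]c1=O` has not. In this assay compound 1 gives 184 ug/mL and compound 3 gives 328 ug/mL. For compound 2 this assay returned only a limit, > 500 ug/mL, namely (the limit of > 500 ug/mL in this assay, at which 1 of the 3 values shown sits). The change hydrogen in place of ethyl on a saturated chain carbon, six bonds along the chain from an aromatic carbon brought an at least 2.7-fold higher number from compound 1 to compound 2 (0.43 log units; beyond the scatter). From compound 3 to compound 4 the same kind of change is made, (hydrogen in place of ethyl on a saturated chain carbon, three bonds along the chain from an aromatic carbon), here three bonds along the chain from an aromatic carbon rather than six, and the cores of compound 1 and compound 3 differ in a way that is not broken down here. Resting on an at least 2.7-fold higher number from compound 1 to compound 2 (0.43 log units; beyond the scatter), compound 4 is expected to show a 2.0-fold higher number from compound 3 to compound 4 (0.30 log units; within the scatter). The estimate for compound 4 in this assay is 650 ug/mL, with a fair chance that only a limit is reported.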

Compound 4, concentration for 50% inhibition: > 500 ug/mL
Compound 4: only a limit was reported; the forecaster's own chance of this, stated with the estimate: 60%; the middle value does not contradict the limit.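

Hydrogen in place of ethyl on the core of compound 3 gives an at least 1.5-fold higher number from compound 3 to compound 4 (0.18 log units; that floor lies within the scatter) and rests on a limit for compound 4, so the true size of this step is unknown. The result does not contradict the change carrying from one core to another, but it does not show that the change carries with the same size: the same change on two cores in this assay, an at least 2.7-fold higher number (0.43 log units; beyond the scatter) from compound 1 to compound 2 and an at least 1.5-fold higher number (0.18 log units; that floor lies within the scatter) from compound 3 to compound 4; the limit leaves it open whether they differ. On each core, the shorter-chain member gives only a limit, compound 2 on one and compound 4 on the other: the limit of > 500 ug/mL in this assay, at which 2 of the 4 values shown sit.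

From the compounds shown here alone, it remains open whether a longer chain on the core of compound 3 would bring a lower number in this assay. Also open, going by these compounds, is how an amine or a carboxylic acid at the chain end would read out on either core.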